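The compounds below may be only part of what the source reports. "The series", "measured", "known", "first", "only" and "open" are said of these compounds alone.

Measured compounds:
compound 1 `O=C(Nc1cccc(-c2oc3cc(-c4ccc(F)cc4)ccc3c(=O)c2O)c1)c1ccc(Br)cc1`, 8630 nM in a functional assay on HCC1937 cells (Homo sapiens) for antiproliferative activity, read by CCK-8 assay, with a stated time of 72 h; a lower number here means a stronger inhibitor, a higher number a weaker inhibitor
compound 2 `Cc1cccc(C(=O)Nc2cccc(-c3oc4cc(-c5ccc(F)cc5)ccc4c(=O)c3O)c2)c1`, 8030 nM in this assay

Compound 2 shows the lowest of the two numbers, though its gap to compound 1 is within the scatter. Compound 3 `O=C(Nc1cccc(-c2oc3cc(-c4ccc(F)cc4)ccc3c(=O)c2O)c1)c1ccc(-c2ccccc2)cc1` differs from compound 2 in one place: 4-phenylphenyl in place of 3-methylphenyl on a carbonyl carbon. For the measured compounds named here, only one measured step bears on this position, a 1.1-fold lower number from compound 1 to compound 2 (0.03 log units; within the scatter), which was within the scatter and exchanged one single ring for another. Going by the values given here, a second ring entering here has no precedent in these data, so no step beyond the scatter is expected, with wide uncertainty. Compound 3 is estimated at 7000 nM, range 2500 nM to 20000 nM, an expected step of a 1.1-fold lower number from compound 2 to compound 3 (0.06 log units; within the scatter).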

Compound 3, half-maximal inhibitory concentration: 44100 nM
The estimate for compound 3 lay 6.3-fold (0.80 log units) below the measured number, and the stated range ends below it.
By their numbers in this assay, from the lowest: compounds 2 and 1 (each within the scatter of the next); then compound 3.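

For the compounds shown here, this position is not indifferent to what sits on the carbonyl carbon: in this assay, the 4-phenylphenyl group gives a 5.5-fold higher number from compound 2 to compound 3 (0.74 log units; beyond the scatter) and so weakens the compound, the first change here beyond the scatter. Phenyl in place of bromo on an aromatic carbon gives a 5.1-fold higher number from compound 1 to compound 3 (0.71 log units; beyond the scatter) and confirms that the second ring is poorly tolerated against both single-ring partners. No measurement here offers a reason for this loss.

Still open, going by these compounds, is whether a single ring carrying an amine or a carboxylic acid would lower the number, and whether any group at this position can bring it well below the values of the single-ring compounds.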